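Methylamino in place of amino on the shared core

The compounds below may be only part of what the source reports. "The series", "measured", "known", "first", "only" and "open" are said of these compounds alone.

For the measured compounds named here, compound 2 `Nc1cc(Oc2ccc(NC(=O)Nc3cccc(C(F)(F)F)c3)cc2)ncn1` stands highest of the two numbers known so far in an assay on isolated protein for inhibition of serine/threonine-protein kinase TNNI3K (Homo sapiens) (on this read-out lower numbers stand for stronger inhibition and higher numbers for weaker inhibition), giving 25 nM. Compound 1 `CNc1cc(Oc2c(F)cc(NC(=O)Nc3cccc(C(F)(F)F)c3)cc2F)ncn1` gives 20 nM in this assay, a value within the scatter of that of compound 2; since the two differ in more than one place, the numbers say only that both sit close together. Compound 3 `CNc1cc(Oc2ccc(NC(=O)Nc3cccc(C(F)(F)F)c3)cc2)ncn1` is yet to be measured in this assay. From compound 2 to compound 3 the change is methyl in place of hydrogen on a nitrogen on an aromatic ring. Going by the values given here, compound 1 already carries the methylamino group and gives 20 nM, yet it differs from compound 2 elsewhere as well, so no step for the methyl alone can be read off from it. Among the compounds with values here, no measured pair isolates this change. The expectation is therefore a step from compound 2 to compound 3 that stays within the usual scatter, with no direction favoured. Compound 3 is estimated at 20 nM in this assay, within a range of 10 nM to 45 nM, which means a step of a 1.3-fold lower number from compound 2 to compound 3 (0.10 log units; within the scatter).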

Compound 3, half-maximal inhibitory concentration: 40 nM
Compound 3: middle estimate off by 2.0-fold (0.30 log units), on the low side; the range from low to high includes it.
By their numbers in this assay, from the lowest: compounds 1, 2 and 3 (each within the scatter of the next).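

In this assay, for the compounds shown here, the change from amino to methylamino reads a 1.6-fold higher number from compound 2 to compound 3 (0.20 log units; within the scatter) and is the first step that isolates this one place. The earlier compounds shown here could not separate the methyl from the other differences between compound 1 and compound 2, whereas this pair shows that, on the shared core, one methyl on a nitrogen on an aromatic ring leaves the number within the scatter of the amino compound and gives no basis for assigning a direction to the step. No measurement among those at hand speaks to what lies behind this step.

On these data alone, this single methyl says little about how much room the position offers: whether an ethyl, a dimethylamino group with both hydrogens replaced, or a longer chain ending in an amine or a carboxylic acid would also stay within the scatter remains open. Also open, as far as these compounds go, is whether the step from amino to methylamino reads the same on the core of compound 1, since a single pair on a single core carries no pattern.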